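Fluoro for bromo on a fused aromatic ring

The source may hold more compounds than are shown below. What is called first, only, known or untested is meant among the compounds shown, and "the series" means these compounds.

Of the compounds shown here, two of a shared core have been measured in a functional assay on the whole organism with Rattus norvegicus as the target, at a dose of 20 mg/kg by the oral route; on this read-out lower numbers stand for less inhibition and higher numbers for more inhibition at the one dose given (going by the name of the read-out). Compound 1 `CON(C)C(=O)/C=C1\CCc2ccc(F)cc21` gives 6% in this assay. Compound 2 `O=C(/C=C1\CCc2ccc(Br)cc21)NC1CC1` gives 29% in this assay, the highest of the two numbers, and its nearest neighbour, compound 1, stands a full step lower, beyond the usual scatter. Compound 3 `O=C(/C=C1\CCc2ccc(F)cc21)NC1CC1` has not yet been measured in this assay. It differs from compound 2 in one place: fluoro in place of bromo on an aromatic carbon. Within the data shown here, no step between two measured compounds shows what this change alone does, since compound 1 and compound 2 differ in more than one place. The step from compound 2 to compound 3 in this assay is expected to be small and downward, possibly within the scatter, a number 11 percentage points lower from compound 2 to compound 3 (beyond the scatter). Compound 3 is therefore estimated to give 18% in this assay, within a range from 2% to 36%.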

Compound 3, a percentage reported as inhibition, in the whole organism at one dose (the size of the read-out at that dose, not a potency): 5%
For compound 3 the middle estimate is 13 percentage points above the measured one; the range from low to high includes it.
By their numbers in this assay, from the lowest: compounds 3 and 1 (each within the scatter of the next); then compound 2.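

Read alone, in this assay, fluoro in place of bromo on this aromatic carbon gives a number 24 percentage points lower from compound 2 to compound 3 (beyond the scatter), so the read-out responds to the group at this position. With fluoro held in place, cyclopropylamino in place of methoxy(methyl)amino on the carbonyl carbon gives a number 1 percentage points lower from compound 1 to compound 3 (within the scatter), so in this pair the exchange on the carbonyl carbon leaves the two values within the scatter of each other. Nothing at hand explains why the read-out responds to the change from bromo to fluoro.

Going by these compounds, whether chloro, iodo or a methyl group on the same carbon would stand nearer to compound 2 or to compound 3 remains open. So does whether the exchange on the carbonyl carbon would also leave the values within the scatter with bromo on the ring.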